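Swapping 2,4-difluorophenyl for 4-bromophenyl on the aromatic nitrogen

The compounds below may be only part of what the source reports. "The series", "measured", "known", "first", "only" and "open" are said of these compounds alone.

In an ADME assay on L6 cells (Rattus norvegicus) for cytotoxicity, read by resazurin assay, with a stated time of 72 h (a lower number here means that less compound is needed, a higher number that more compound is needed for the effect), compound 3 `CCOC(=O)C1=C(C)N/C(=C/c2cc(C)n(-c3ccc(F)cc3F)c2C)C1=O` gives 14000 nM, the lowest number of the three compounds measured. Compound 1 `CCOC(=O)C1=C(C)N/C(=C/c2cc(C)n(-c3ccc(CN(C)C)cc3)c2C)C1=O` gives 120000 nM, and compound 2 `CCOC(=O)C1=C(O)/C(=C\c2cc(C)n(-c3ccc(F)cc3)c2C)N=C1C` gives 140000 nM. Compound 4 `CCOC(=O)C1=C(C)N/C(=C/c2cc(C)n(-c3ccc(Br)cc3)c2C)C1=O` has not yet been measured. It carries 4-bromophenyl in place of 2,4-difluorophenyl on an aromatic nitrogen. Among the compounds with values here, the only measured step at that place is an 8.6-fold lower number from compound 1 to compound 3 (0.93 log units; beyond the scatter). Within the data shown here, that step shows that the group on this nitrogen can shift the number in this assay, but no measured compound carries bromine, so the evidence is thin. Compound 3 alone holds 2,4-difluorophenyl, and it stands apart from the other two, so losing that group is expected to raise the number, though by less than the measured step. The expected change is a 2.5-fold higher number from compound 3 to compound 4 (0.40 log units; beyond the scatter). For compound 4 the estimate is 35000 nM, with an expected range from 10000 nM to 120000 nM.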

Compound 4, half-maximal effective concentration: 100000 nM
Beside the measured number, compound 4's estimate is 2.9-fold (0.46 log units) below it; measured number inside the range.
By their numbers in this assay, from the lowest: compound 3; then compounds 4, 1 and 2 (each within the scatter of the next).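

In this assay, 4-bromophenyl in place of 2,4-difluorophenyl on the aromatic nitrogen gives a 7.1-fold higher number from compound 3 to compound 4 (0.85 log units; beyond the scatter) and so removes most of the advantage held by compound 3. Bromo in place of (dimethylamino)methyl on an aromatic carbon gives a 1.2-fold lower number from compound 1 to compound 4 (0.08 log units; within the scatter) and so leaves these two groups indistinguishable in this assay. Among the compounds that can be compared in one place, the low number therefore stays with 2,4-difluorophenyl alone, and nothing available here explains why.

Going by these compounds, what remains open is whether both fluorines of that group are needed for the low number. On these data alone, it is also open how a chlorine, a methoxy group or a carboxylic acid on the same phenyl ring would read.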